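Urea-linked series: replacing the methoxyphenyl by an aminoalkyl chain

The source may hold more compounds than are shown below. What is called first, only, known or untested is meant among the compounds shown, and "the series" means these compounds.

Measured compounds, in a functional assay on A549 cells (Homo sapiens) for antiproliferative activity, read by MTT assay, with a stated time of 72 h; a higher number here means a weaker inhibitor, a lower number a stronger inhibitor:
compound 1 `O=C(Nc1ccc(CN2CCCC2)cc1)Nc1ccc2ncnc(Nc3cccc(C(F)(F)F)c3)c2c1` gives 830 nM
compound 2 `CN(C)Cc1ccc(NC(=O)Nc2ccc3ncnc(Nc4cccc(C(F)(F)F)c4)c3c2)cc1` gives 1120 nM
compound 3 `COc1ccc(NC(=O)Nc2ccc3ncnc(Nc4cccc(C(F)(F)F)c4)c3c2)cc1` gives 9470 nM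

Compound 3 stands highest of the three numbers in this assay. The two steps that reach it are large: an 11-fold higher number from compound 1 to compound 3 (1.06 log units; beyond the scatter) and an 8.5-fold higher number from compound 2 to compound 3 (0.93 log units; beyond the scatter). Between the two aminomethyl-bearing compounds the step is small, a 1.3-fold higher number from compound 1 to compound 2 (0.13 log units; within the scatter).

Compound 4 `CN1CCN(CCNC(=O)Nc2ccc3ncnc(Nc4cccc(C(F)(F)F)c4)c3c2)CC1` is not yet measured. It differs from compound 3 as follows: 2-(4-methylpiperazin-1-yl)ethyl in place of 4-methoxyphenyl on an amide-type nitrogen. Within the data shown here, the change brings back a group with two nitrogen atoms on the urea side, which in compound 1 and compound 2 went with the lower numbers, but it also removes the aromatic ring of the 4-methoxyphenyl group, and no measured step shows that removal on its own. The steps to compound 3 therefore bear on it only in part.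

The number for compound 4 is expected to fall against compound 3, by about a 3.8-fold lower number from compound 3 to compound 4 (0.58 log units; beyond the scatter), with a wide range. The estimate for compound 4 in this assay is 2500 nM, between 600 nM and 10000 nM.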

Compound 4, half-maximal inhibitory concentration: > 10000 nM
Compound 4 gave a limit, no number; the forecaster's own chance of this, stated with the estimate: 5%; at least 4.0-fold (0.60 log units) between middle value and limit.
By their numbers in this assay, from the lowest: compounds 1 and 2 (each within the scatter of the next); then compound 3. At a limit, above all of these: compound 4.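

Compound 4 stands as a limit and not a number in this assay: the limit of > 10000 nM in this assay, at which 1 of the 4 values shown sits.

Amine nitrogens on the urea side are therefore not enough for the lower numbers at this amide-type nitrogen: the 2-(4-methylpiperazin-1-yl)ethyl group gives an at least 8.9-fold higher number from compound 2 to compound 4 (0.95 log units; beyond the scatter) and an at least 12-fold higher number from compound 1 to compound 4 (1.08 log units; beyond the scatter), so compound 1 and compound 2, which keep an aromatic ring on this nitrogen, are the only compounds here that pair an amine with the lower numbers. Against the methoxy compound the reading is an at least 1.0-fold higher number from compound 3 to compound 4 (0.02 log units; that floor lies within the scatter), a floor within the scatter, so compound 4 may lie close to compound 3 or far past it.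

The compounds shown do not separate the loss of the aromatic ring from the nature of the amine. A 4-((4-methylpiperazin-1-yl)methyl)phenyl group or a 2-(pyrrolidin-1-yl)ethyl chain on the same nitrogen would bear on that question.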